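The source may hold more compounds than are shown below. What is called first, only, known or untested is meant among the compounds shown, and "the series" means these compounds.

Values in a functional assay on HepG2 cells (Homo sapiens) for antiproliferative activity, read by MTT assay, with a stated time of 24 h; on this read-out higher numbers stand for weaker inhibition and lower numbers for stronger inhibition:
- compound 1 `COC(=O)c1scc(-c2ccc(NC(=O)c3ccc(F)c(Cl)n3)cc2)c1OC`: 10300 nM
- compound 2 `COC(=O)c1scc(-c2ccc(NC(=O)c3cccc(I)c3)cc2)c1OC`: 16500 nM
- compound 3 `COC(=O)c1scc(-c2ccc(NC(=O)c3ccc(OC)nc3)cc2)c1OC`: > 50000 nM (a limit, not a number)

Compound 1 holds the lowest of the two true numbers, but compound 2 sits within the scatter of it: a 1.6-fold higher number from compound 1 to compound 2 (0.20 log units; within the scatter). The limit reached by compound 3 lies beyond the scatter from both others: an at least 4.8-fold higher number from compound 1 to compound 3 (0.68 log units; beyond the scatter), and an at least 3.0-fold higher number from compound 2 to compound 3 (0.48 log units; beyond the scatter).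

Compound 4 `COC(=O)c1scc(-c2ccc(NC(=O)c3ccc(C(F)(F)F)cc3)cc2)c1OC` is still unmeasured and differs from compound 1 as follows: 4-(trifluoromethyl)phenyl in place of 6-chloro-5-fluoropyridin-2-yl on a carbonyl carbon. In words, 4-(trifluoromethyl)phenyl takes the place of 6-chloro-5-fluoropyridin-2-yl on a carbonyl carbon.

The closest measured precedent is compound 2, which also carries a ring of carbon only on the carbonyl, and that exchange stayed within the scatter: a 1.6-fold higher number from compound 1 to compound 2 (0.20 log units; within the scatter). For the measured compounds named here, the 6-methoxypyridin-3-yl group of compound 3 is the only exchange that moved the read-out clearly, and it has no close counterpart in compound 4. Three compounds support no firm trend, so a limit result for compound 4 cannot be ruled out.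

In this assay the expected change is small and towards a slightly higher number, not beyond the scatter: a 1.5-fold higher number from compound 1 to compound 4 (0.16 log units; within the scatter).

For compound 4 the estimated value is 15000 nM, with an expected range from 6000 nM to 40000 nM.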

Compound 4, half-maximal inhibitory concentration: 24600 nM
Compound 4: middle estimate off by 1.6-fold (0.21 log units), on the low side; low and high end bracket the measured number.
By their numbers in this assay, from the lowest: compounds 1, 2 and 4 (each within the scatter of the next, the first and the last beyond it). At a limit, above all of these: compound 3.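

In this assay, a carbon-only ring on the carbonyl carbon is no longer always interchangeable with 6-chloro-5-fluoropyridin-2-yl: 4-(trifluoromethyl)phenyl gives a step beyond the scatter, a 2.4-fold higher number from compound 1 to compound 4 (0.38 log units; beyond the scatter), whereas 3-iodophenyl gave one within it, a 1.6-fold higher number from compound 1 to compound 2 (0.20 log units; within the scatter). The two carbon-only rings are not separated from each other at this position, a 1.5-fold higher number from compound 2 to compound 4 (0.17 log units; within the scatter), so the data support only a modest loss for one of them against compound 1 and no ranking between them. The remaining step starts from a limit, not a number, and gives only a floor, an at least 2.0-fold lower number from compound 3 to compound 4 (0.30 log units; that floor lies within the scatter), which leaves that pair unseparated: the limit of > 50000 nM in this assay, at which 1 of the 4 values shown sits.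

The compounds shown do not tell whether the ring nitrogen, the halogens or the place of the substituent accounts for the step from 6-chloro-5-fluoropyridin-2-yl, as these differ together in every pair. Also open, on these data alone, is how the read-out responds to an amine or a carboxylic acid on this ring, or to a saturated alkyl chain on the carbonyl carbon in place of the ring.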